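The source may hold more compounds than are shown below. What is called first, only, known or untested is meant among the compounds shown, and "the series" means these compounds.

Measured so far:
- compound 1 `Cc1ccccc1Nc1nc(Nc2ccc(N3CCN(C)CC3)cn2)ncc1Cl`: 5210 nM
- compound 2 `Cc1ccccc1Nc1nc(Nc2ccc(N3CCCN(C)CC3)cc2)ncc1Cl`: 4290 nM

Both compounds were tested in a functional assay on MCF7 cells (Homo sapiens) for inhibition, read by CCK-8 assay, with a stated time of 48 h; on this read-out higher numbers stand for weaker inhibition of growth and lower numbers for stronger inhibition of growth. Compound 1 gives 5210 nM in this assay, and compound 2 gives 4290 nM. Going by the values given here, the two numbers lie within the usual scatter of each other, so this assay does not separate compound 1 from compound 2; compound 1 simply stands at the same level as the only other compound measured. The two differ from each other in more than one place, so no single structural step can be read from their pair.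

The next compound, compound 3 `CCc1ccc(Nc2nc(Nc3ccc(N4CCN(C)CC4)cn3)ncc2Cl)cc1`, is not yet measured. It departs from compound 1 in one place: 4-ethylphenyl in place of 2-methylphenyl on a nitrogen on an aromatic ring. Among the compounds with values here, no measured pair shows the effect of this kind of exchange, so there is nothing in the data to set a direction for the step. The expectation is therefore a step of no more than the scatter, in either direction. Compound 3 is expected to give about 5000 nM in this assay, with a likely range from 1500 nM to 16000 nM. This estimate corresponds to an expected step of a 1.0-fold lower number from compound 1 to compound 3 (0.02 log units; within the scatter), which stays within the scatter.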

Compound 3, concentration for 50% growth inhibition: 8230 nM
Beside the measured number, compound 3's estimate is 1.6-fold (0.22 log units) below it, within the range that was stated.
By their numbers in this assay, from the lowest: compounds 2, 1 and 3 (each within the scatter of the next).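

Going by these compounds alone, this is the first exchange at this position that can be read on its own: in this assay, putting 4-ethylphenyl in place of 2-methylphenyl on the nitrogen gives a 1.6-fold higher number from compound 1 to compound 3 (0.20 log units; within the scatter), so this assay does not tell the two compounds apart. The two groups are both built on a six-membered aromatic ring of carbon only, and the result shows that this particular swap, which alters both the alkyl chain and where it is attached, leaves no readable mark on growth inhibition. No separate measurement is available here that would explain this outcome.

Because the chain and its place on the ring differ together, the compounds shown cannot separate the contribution of one from the other, and a plain phenyl, 2-ethylphenyl or 4-methylphenyl would be needed to do so. Also open, from the compounds shown here alone, is whether a group containing atoms other than carbon on this ring, such as a methoxy group, an amine or a carboxylic acid, would produce a step beyond the usual scatter.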